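A few compounds are considered here, and "the series" means these few. Any claim that something is new, unique, unknown or untested is made for them only; others in the source may bear on it.

Working notes on the series. Four compounds share one core: compound 1 `O=C1/C(=C/c2cccnc2)CN(S(=O)(=O)c2ccc(F)cc2)C/C1=C\c1ccccc1F`, compound 2 `O=C1/C(=C/c2cccnc2)CN(S(=O)(=O)c2ccc(Cl)cc2)C/C1=C\c1ccccc1F`, compound 3 `O=C1/C(=C/c2ccncc2)CN(S(=O)(=O)c2ccc(F)cc2)C/C1=C\c1ccccc1F` and compound 4 `O=C1/C(=C/c2ccncc2)CN(S(=O)(=O)c2ccc(Cl)cc2)C/C1=C\c1ccccc1F`, the last not yet tested. In an ADME assay on L02 cells (Homo sapiens) for cytotoxicity, read by MTT assay, with a stated time of 24 h (a lower number here means a stronger inhibitor, a higher number a weaker inhibitor), compound 1 gives 15600 nM. Compound 2 reaches only a limit of this assay, > 20000 nM, which is the limit of > 20000 nM in this assay, at which 1 of the 3 values shown sits. Compound 3 gives 15600 nM in this assay.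

Two changes are measured. From compound 1 to compound 2 the change is chloro in place of fluoro on an aromatic carbon and the step is an at least 1.2-fold higher number from compound 1 to compound 2 (0.10 log units; that floor lies within the scatter). From compound 1 to compound 3 the change is pyridin-4-yl in place of pyridin-3-yl on a double-bonded chain carbon bound to a double-bonded ring carbon, with the step of no change at the digits printed from compound 1 to compound 3 (within the scatter); this is also how the core of compound 3 differs from the core of compound 1.

Compound 4 differs from compound 3 by chloro in place of fluoro on an aromatic carbon, the same change as from compound 1 to compound 2, at the same place in the same words. Because compound 1 to compound 2 showed an at least 1.2-fold higher number from compound 1 to compound 2 (0.10 log units; that floor lies within the scatter), the expected step is a 1.4-fold higher number from compound 3 to compound 4 (0.15 log units; within the scatter). Compound 4 is therefore expected to give 22000 nM, most likely between 13000 nM and 40000 nM, and quite possibly only a limit again.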

Compound 4, half-maximal inhibitory concentration: 15000 nM
Estimate against measurement, compound 4: 1.5-fold (0.17 log units) above; measured number inside the range.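

In this assay the swap of chloro for fluoro on the core of compound 3 gives a 1.0-fold lower number from compound 3 to compound 4 (0.02 log units; within the scatter), and the swap of pyridin-4-yl for pyridin-3-yl on the chloro compounds gives an at least 1.3-fold lower number from compound 2 to compound 4 (0.12 log units; that floor lies within the scatter). These results show no step beyond the scatter for the chloro change on the pyridin-4-yl core, but they do not show that the change carries over unaltered from the pyridin-3-yl core or that it behaves differently there: the same change on two cores in this assay, an at least 1.2-fold higher number (0.10 log units; that floor lies within the scatter) from compound 1 to compound 2 and a 1.0-fold lower number (0.02 log units; within the scatter) from compound 3 to compound 4; the limit leaves it open whether they differ. The pyridine change likewise cannot be called the same or different on the fluoro and chloro compounds: the same change on two cores in this assay, no change at the digits printed (within the scatter) from compound 1 to compound 3 and an at least 1.3-fold lower number (0.12 log units; that floor lies within the scatter) from compound 2 to compound 4; the limit leaves it open whether they differ.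

Going by these compounds, the size of the steps that involve compound 2 stays open, since only a floor is available for each. Also open, on these data alone, is whether groups other than fluoro and chloro on that aromatic carbon, such as an amine or a carboxylic acid, would give a step beyond the scatter in this assay.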